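The source may hold more compounds than are shown below. What is called first, only, known or untested is meant among the compounds shown, and "the series" means these compounds.

Measured compounds in a functional assay on MGC-803 cells (Homo sapiens) for antiproliferative activity, read by MTT assay, with a stated time of 72 h; a higher number here means a weaker inhibitor, a lower number a stronger inhibitor:
compound 1 `CCCSc1nc(N/N=C(\C)c2ccc(OC)cc2)c2nnn(Cc3ccccc3)c2n1` gives 44300 nM
compound 2 `CCCSc1nc(N/N=C/c2ccc(N(C)C)cc2)c2nnn(Cc3ccccc3)c2n1` gives 13100 nM
compound 3 `C#CCSc1nc(N/N=C/c2ccc(N(C)C)cc2)c2nnn(Cc3ccccc3)c2n1` gives 7620 nM

Compound 2 stands second highest of the three numbers; compound 3 is nearest, a 1.7-fold lower number from compound 2 to compound 3 (0.24 log units; within the scatter), and compound 1 sits furthest, with the higher number of the two. Compound 4 `CCCSc1nc(N/N=C/c2c(O)ccc3ccccc23)c2nnn(Cc3ccccc3)c2n1` is not yet measured. It differs from compound 2 in one place: 2-hydroxynaphthalen-1-yl in place of 4-(dimethylamino)phenyl on a carbon with a double bond to nitrogen. Among the measured compounds shown here, no measured step touches the group on the carbon with a double bond to nitrogen; the only measured step, a 1.7-fold lower number from compound 2 to compound 3 (0.24 log units; within the scatter), concerns the chain on the sulfur and is within the scatter. The expectation for the step of a 1.1-fold lower number from compound 2 to compound 4 (0.04 log units; within the scatter) is therefore no change beyond the scatter, in either direction. Compound 4 is estimated at 12000 nM, with a range of 3000 nM to 45000 nM in this assay.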

Compound 4, half-maximal inhibitory concentration: 3710 nM
For compound 4 the middle estimate is 3.2-fold (0.51 log units) above the measured one; measured number inside the range.
By their numbers in this assay, from the lowest: compound 4; then compounds 3 and 2 (each within the scatter of the next); then compound 1.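

In this assay the group on the carbon with a double bond to nitrogen is a place where the number moves, with a 3.5-fold lower number from compound 2 to compound 4 (0.55 log units; beyond the scatter) set against a change on the chain on the sulfur that stayed within the scatter. The change swaps 4-(dimethylamino)phenyl for 2-hydroxynaphthalen-1-yl, so the loss of the dimethylamino group, the gain of the hydroxy group and the larger aromatic system all arrive in one step. No measurement at hand explains the step.

The compounds shown do not say which of these parts carries the step. A plain naphthalen-1-yl or a 2-hydroxyphenyl group on that carbon would begin to separate them.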